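The source may report more compounds than this note shows. Statements on the series, on what has been measured and on what is new or still open speak of the compounds shown alone.

Measured compounds:
compound 1 `Cc1cc([Si](C)(C)C)c2cn[nH]c2c1`: 50%
compound 2 `C[Si](C)(C)c1cccc2[nH]ncc12`: 7.2%
compound 3 `OC(Cc1ccccc1)c1cc(Br)cc2[nH]ncc12`: 90%

In an assay for inhibition of Indoleamine 2,3-dioxygenase 1 (Homo sapiens), read by spectrophotometry, with a stated time of 30 min, tested at 10 uM (on this read-out lower numbers stand for less inhibition and higher numbers for more inhibition at the one concentration tested (going by the name of the read-out)), compound 3 gives the highest of the three numbers shown; compound 1 sits lower by a gap beyond the scatter, and compound 2 lower still, also beyond the scatter. Compound 4 `OC(Cc1ccccc1)c1cc(-c2ccccc2)cc2[nH]ncc12` is the next case. Its change from compound 3: phenyl in place of bromo on an aromatic carbon, on an aromatic carbon of a six-membered aromatic ring of carbon only, meta to a fused ring. For the measured compounds named here, the one measured step, a number 42.8 percentage points lower from compound 1 to compound 2 (beyond the scatter), concerns a different exchange (hydrogen in place of methyl) and does not bear on bromo against phenyl. Going by the values given here, no measured step therefore tells the size or direction of the change. The expected step is a number 10 percentage points lower from compound 3 to compound 4 (within the scatter), kept small given that compound 3 already stands at 90%. Compound 4 is estimated at 80%, within 50% to 95%.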

Compound 4, a percentage reported as inhibition, at one concentration (the size of the read-out at that concentration, not a potency): 4%
Beside the measured number, compound 4's estimate is 76 percentage points above it; the whole stated range lies above it.
By their numbers in this assay, from the lowest: compounds 4 and 2 (each within the scatter of the next); then compound 1; then compound 3.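

In this assay, phenyl in place of bromo on this aromatic carbon, meta to a fused ring, gives a number 86 percentage points lower from compound 3 to compound 4 (beyond the scatter) and so shows that the read-out depends strongly on the group at this position. For the compounds shown here, the earlier step covered only hydrogen against methyl in a different pair, so this is the first sign that bromo cannot be exchanged freely here. No available evidence accounts for the drop. Still open, as far as these compounds go, is how groups other than bromo and phenyl behave on this carbon. An amine, a methoxy group or a carboxylic acid there would show whether the loss is particular to phenyl.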